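Replacing an oxazole amide with a pyrimidine on the ring nitrogen

This account rests on a few compounds, and the source may have more. Where it says the series, first, only, none or still open, it means among the compounds named here.

Of the compounds shown here, three have been measured in a physicochemical assay for lipophilicity, read by HPLC, measured as chromatographic lipophilicity, at pH 7.4; on this read-out lower numbers stand for lower lipophilicity and higher numbers for higher lipophilicity. Compound 1 `CC(C)(CN)C(=O)N1N=CCC1c1ccccc1` gives 1.4, compound 3 `O=C(c1ccccc1)N1N=CCC1c1ccccc1` gives 4.6, and compound 2 `O=C(c1cnco1)N1CCC(C(=O)N2N=CC[C@H]2c2ccccc2)CC1` gives 2.7, which is the second highest of the three, above compound 1 and below compound 3. For the measured compounds named here, the only step between measured compounds is a number 3.20 log units higher from compound 1 to compound 3 (beyond the scatter). Compound 4 `O=C(C1CCN(c2ncccn2)CC1)N1N=CC[C@H]1c1ccccc1` differs from compound 2 in one place: pyrimidin-2-yl in place of (1,3-oxazol-5-yl)carbonyl on an amine nitrogen in a ring. That step does not match the measured one, so guidance is indirect; the change swaps an aromatic carbonyl for a bare aromatic ring, and an upward step in this assay is expected, estimated as a number 1.00 log units higher from compound 2 to compound 4 (beyond the scatter). Compound 4 is therefore expected to reach about 3.7, within a range of 3 to 4.4.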

Compound 4, distribution coefficient: 4.7
The estimate for compound 4 lay 1.00 log units below the measured number; the whole stated range lies below it.
By their numbers in this assay, from the lowest: compound 1; then compound 2; then compounds 3 and 4 (each within the scatter of the next).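

On the amine nitrogen in the six-membered ring, pyrimidin-2-yl in place of (1,3-oxazol-5-yl)carbonyl gives a number 2.00 log units higher from compound 2 to compound 4 (beyond the scatter) in this assay as a large rise. For the compounds shown here, the only earlier step was on a carbonyl carbon, so this shows that a single change on this ring nitrogen can also move the read-out strongly. Nothing available explains the size of this step.

Still open, going by these compounds, is whether the step follows the loss of the carbonyl or the change of ring. A pyrimidin-2-ylcarbonyl group on that nitrogen would keep the carbonyl while carrying the new ring.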